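The compounds below may be only part of what the source reports. "The series", "measured", "known", "first", "only" and "open" are said of these compounds alone.

Measured compounds in a functional assay on GTL 16 cells for antiproliferative activity against GTL 16 cell line (Homo sapiens), read by CCK-8 assay, with a stated time of 72 h; a higher number here means a weaker inhibitor, a lower number a stronger inhibitor:
Compound 1 `O=C(Nc1cccc(-c2oc3cc(-c4ccc(F)cc4)ccc3c(=O)c2O)c1)c1ccc(Cl)cc1` gives 9140 nM in this assay.
Compound 2 `O=C(Nc1cccc(-c2oc3cc(-c4ccc(F)cc4)ccc3c(=O)c2O)c1)c1ccc(F)cc1F` gives 9640 nM in this assay.
Compound 3 `Cc1cccc(C(=O)Nc2cccc(-c3oc4cc(-c5ccc(F)cc5)ccc4c(=O)c3O)c2)c1` gives 10900 nM in this assay.

All three compounds share the same core and differ only in the aromatic group attached to the amide carbonyl. The steps between them are all small: a 1.1-fold higher number from compound 1 to compound 2 (0.02 log units; within the scatter), a 1.2-fold higher number from compound 1 to compound 3 (0.08 log units; within the scatter) and a 1.1-fold higher number from compound 2 to compound 3 (0.05 log units; within the scatter). Compound 2 therefore sits among numbers that cannot be told apart from one another in this assay.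

Compound 4 `O=C(Nc1cccc(-c2oc3cc(-c4ccc(F)cc4)ccc3c(=O)c2O)c1)c1cccc(F)c1` is obtained from compound 2 by the change (3-fluorophenyl in place of 2,4-difluorophenyl on a carbonyl carbon). The measured steps that bear on this are the exchanges of the same aromatic group seen from compound 1 to compound 2 and from compound 2 to compound 3, both of which stayed within the scatter. A fluorine-bearing phenyl of a different pattern is therefore expected to behave alike, giving no step beyond the scatter in this assay. Compound 4 is estimated at 9600 nM, within 5000 nM to 18000 nM, which means an expected step of a 1.0-fold lower number from compound 2 to compound 4 (0.00 log units; within the scatter).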

Compound 4, half-maximal inhibitory concentration: 15800 nM
Estimate against measurement, compound 4: 1.6-fold (0.22 log units) below; measured number inside the range.
By their numbers in this assay, from the lowest: compounds 1, 2, 3 and 4 (each within the scatter of the next).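

In this assay the 3-fluorophenyl group, with its single fluorine, gives a 1.6-fold higher number from compound 2 to compound 4 (0.21 log units; within the scatter) and a 1.4-fold higher number from compound 3 to compound 4 (0.16 log units; within the scatter) and also a 1.7-fold higher number from compound 1 to compound 4 (0.24 log units; within the scatter) and so still shows no readable effect at this position. Going by these compounds alone, these are the widest steps so far, yet the four phenyl groups on this carbonyl carbon, bearing chloro, fluoro or methyl, cannot be told apart in this assay. No measurement shown here offers an explanation for these numbers.

As far as these compounds go, all four groups are substituted phenyl rings, so it remains open whether an amine, a carboxylic acid or a longer carbon chain on this carbonyl carbon would give a step beyond the scatter. The rest of the shared core is identical in all four compounds, which leaves the effect of changes elsewhere on it unknown.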